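The compounds below may be only part of what the source reports. "The series", "measured", "known", "first", "only" and "open" are said of these compounds alone.

Compound 1 `O=C(c1ccn(-c2ccc3c(c2)B(O)OC3)c1)c1ccc(Cl)cc1Cl`: in an ADME assay on L929 cells (Mus musculus) for cytotoxicity, read by resazurin assay, with a stated time of 72 h (on this read-out lower numbers stand for stronger inhibition and higher numbers for weaker inhibition), compound 1 gives > 10 ug/mL, which is a limit of the assay rather than a number.
Compound 2 `O=C(c1ccccc1)c1ccn(-c2ccc3c(c2)B(O)OC3)c1`: in this assay compound 2 gives > 10 ug/mL, again a limit.
Compound 3 `O=C(c1cccc(Cl)c1)c1ccn(-c2ccc3c(c2)B(O)OC3)c1`: in this assay compound 3 gives > 10 ug/mL, also a limit.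

All three values sit at the limit of > 10 ug/mL in this assay, at which 3 of the 3 values shown sit, so compound 3 stands where the others stand, with no readable number of its own. The change to compound 4 `Cc1ccc(C(=O)c2ccn(-c3ccc4c(c3)B(O)OC4)c2)cc1` is 4-methylphenyl in place of 3-chlorophenyl on a carbonyl carbon. The measured steps that touch the same position, a step that the two limits leave unreadable from compound 1 to compound 3 and a step that the two limits leave unreadable from compound 2 to compound 3, carry no readable size; both of their ends are limits. Nothing here points to a step beyond the scatter in this assay. The expected step is a step that the limit leaves unreadable from compound 3 to compound 4, within the usual scatter. Compound 4 is estimated at 15 ug/mL, between 7 ug/mL and 40 ug/mL, most likely reported again only as a limit.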

Compound 4, half-maximal inhibitory concentration: > 10 ug/mL
Compound 4: a limit, no number; the forecaster's own chance of this, stated with the estimate: 80%; the middle value does not contradict the limit.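

In this assay compound 4 gives > 10 ug/mL, a limit and not a number. Its steps from compound 1, compound 2 and compound 3 cannot be read. The compounds shown leave open at what concentration each would inhibit these cells, and whether they differ at all: the limit of > 10 ug/mL in this assay, at which 4 of the 4 values shown sit.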